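The source may report more compounds than this note shows. Statements on the series, on what has been measured and on what is new or still open speak of the compounds shown alone.

Compound 1 `Cc1cc(S(=O)(=O)N2[C@H](CO)CC[C@@H]2c2ccc(F)cc2)cc(C)c1F`: 63 nM. Compound 2 `CNC[C@@H]1CC[C@H](c2ccc(F)cc2)N1S(=O)(=O)c1cc(C)c(F)c(C)c1`: > 20000 nM. Compound 3 `O=S(=O)(c1ccccc1)N1[C@H](CO)CC[C@@H]1c1ccc(F)cc1`: > 19000 nM.

In an assay on isolated protein for inhibition of transient receptor potential cation channel subfamily A member 1 (Homo sapiens) (a higher number here means a weaker inhibitor, a lower number a stronger inhibitor), compound 1 gives 63 nM. Compound 2 reaches only the limit > 20000 nM. Within the data shown here, the one measured step, an at least 310-fold higher number from compound 1 to compound 2 (2.50 log units; beyond the scatter), ends at that limit (the limit of > 20000 nM in this assay, at which 1 of the 3 values shown sits). Compound 3 likewise stands at a limit, > 19000 nM, the weak end of what is shown (the limit of > 19000 nM in this assay, at which 1 of the 3 values shown sits). Compound 4 `Cc1cc(S(=O)(=O)N2[C@H](CO)CC[C@@H]2c2ccc(F)cc2)ccc1F` carries 4-fluoro-3-methylphenyl in place of phenyl on a sulfonyl sulfur. Among the measured compounds shown here, no measured step covers this change; the values of compound 1 and compound 3 only show that the fluorine- and methyl-bearing ring goes with a far lower number than the bare phenyl. Compound 4 is therefore expected to gain strongly, an at least 38-fold lower number from compound 3 to compound 4 (1.57 log units; beyond the scatter), with an estimate of 500 nM between 100 nM and 5000 nM.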

Compound 4, half-maximal inhibitory concentration in the transient receptor potential cation channel subfamily A member 1 assay: 190 nM
For compound 4 the middle estimate is 2.6-fold (0.42 log units) above the measured one, within the range that was stated.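

In the transient receptor potential cation channel subfamily A member 1 assay, 4-fluoro-3-methylphenyl in place of phenyl on the sulfonyl sulfur gives an at least 100-fold lower number from compound 3 to compound 4 (2.00 log units; beyond the scatter), so a single added methyl together with the fluorine is enough for most of this gain. Compound 3 stands at a limit: the limit of > 19000 nM in the transient receptor potential cation channel subfamily A member 1 assay, at which 1 of the 4 values shown sits. Hydrogen in place of methyl on an aromatic carbon gives only a 3.0-fold higher number from compound 1 to compound 4 (0.48 log units; beyond the scatter), a modest loss beside that gain.

Which of fluorine or methyl carries the gain stays open, as does the effect of an amine or a carboxylic acid on this ring. In a physicochemical assay for lipophilicity, at pH 7.4 (a higher number here means a more lipophilic compound, a lower number a more polar compound), compound 3 gives 2.2 and compound 4 gives 2.8. The ring change also does not separate potency from lipophilicity in the physicochemical assay: the measured distribution coefficient of compound 3, 2.2, and of compound 4, 2.8, a number 0.60 log units higher (beyond the scatter)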